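The compounds below may be only part of what the source reports. "The series", "measured", "known", "first", "only" and "open" are said of these compounds alone.

Compound 1 `CCc1cc2ccccc2nc1-c1cc(-c2ccc(C(F)(F)F)cc2)no1` reaches only a limit in a functional assay on COLO 205 cells (Homo sapiens) for inhibition, read by MTT assay, with a stated time of 24 h (a lower number here means a stronger inhibitor, a higher number a weaker inhibitor), recorded as > 100000 nM. Among the compounds with values here, compound 2 `CCCc1cc2ccccc2nc1-c1cc(-c2ccc(C(F)(F)F)cc2)no1` gives 42200 nM in this assay, the only true number among the values shown. That move was an at least 2.3-fold lower number from compound 1 to compound 2 (0.37 log units; beyond the scatter). Compound 3 `CCCCCc1cc2ccccc2nc1-c1cc(-c2ccc(C(F)(F)F)cc2)no1` differs from compound 2 by ethyl in place of hydrogen on a saturated chain carbon, three bonds along the chain from an aromatic carbon. Within the data shown here, the single measured step bears on this change and lowered the number, so a further modest lowering is expected. Compound 3 is estimated at 20000 nM, with a range from 5000 nM to 70000 nM. The step expected is a 2.1-fold lower number from compound 2 to compound 3 (0.32 log units; beyond the scatter).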

Compound 3, half-maximal inhibitory concentration: 24500 nM
Compound 3: the middle estimate sits 1.2-fold (0.09 log units) below what was measured; the measured number falls inside the stated range.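

In this assay, ethyl in place of hydrogen at this chain carbon gives a 1.7-fold lower number from compound 2 to compound 3 (0.24 log units; within the scatter), so this further lengthening brings no change that can be read. Propyl in place of hydrogen at the chain carbon two bonds along still gives an at least 4.0-fold lower number from compound 1 to compound 3 (0.61 log units; beyond the scatter). That step is only a bound, because compound 1 stands at a limit: the limit of > 100000 nM in this assay, at which 1 of the 3 values shown sits.

From the compounds shown here alone, whether a chain longer than pentyl would move the number beyond the scatter stays open. So does the effect of an amine or a carboxylic acid at the end of this chain.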